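The compounds below may be only part of what the source reports. "The series", "measured", "known", "first", "only" and "open" are said of these compounds alone.

In a functional assay on MCF7 cells (Homo sapiens) for cytotoxicity, read by MTT assay, with a stated time of 72 h (on this read-out higher numbers stand for weaker inhibition and lower numbers for stronger inhibition), compound 1 `COc1cc2ncnc(NNC(=S)NC(=O)c3ccc(Cl)cc3)c2cc1OC` gives 8940 nM and compound 2 `O=C(NC(=S)NNc1ncnc2ccccc12)c1ccc(Cl)cc1` gives 5960 nM; the difference between these two cores is not broken down here. Relative to compound 1, compound 3 `COc1cc2ncnc(NNC(=S)NC(=O)c3ccc(C(F)(F)F)cc3)c2cc1OC` carries the change (trifluoromethyl in place of chloro on an aromatic carbon); in this assay compound 3 gives 16800 nM, a step of a 1.9-fold higher number from compound 1 to compound 3 (0.27 log units; within the scatter). Compound 4 `O=C(NC(=S)NNc1ncnc2ccccc12)c1ccc(C(F)(F)F)cc1` carries the same change against compound 2, (trifluoromethyl in place of chloro on an aromatic carbon), and awaits measurement in this assay. Going by the values given here, because the one measured step of this kind, a 1.9-fold higher number from compound 1 to compound 3 (0.27 log units; within the scatter), stays within the scatter, a step of comparable size is expected from compound 2 to compound 4, a 1.8-fold higher number from compound 2 to compound 4 (0.27 log units; within the scatter), on the assumption that the core of compound 2 responds to the change as the core of compound 1 did. Compound 4 is therefore estimated at 11000 nM, with a likely range from 5000 nM to 25000 nM.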

Compound 4, half-maximal inhibitory concentration: 8050 nM
Beside the measured number, compound 4's estimate is 1.4-fold (0.14 log units) above it; the measured number falls inside the stated range.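

In this assay trifluoromethyl in place of chloro on the aromatic carbon gives a 1.4-fold higher number from compound 2 to compound 4 (0.13 log units; within the scatter) and so repeats, on a second core, a step that stays within the scatter. Set beside the earlier step, the new one does not differ from it: the same change on two cores in this assay, a 1.9-fold higher number (0.27 log units; within the scatter) from compound 1 to compound 3 and a 1.4-fold higher number (0.13 log units; within the scatter) from compound 2 to compound 4, 1.4-fold (0.14 log units) apart, within the scatter of two such steps. The change thus behaves alike on these two cores, but neither step shows that it shifts the number on its core, and two pairs cannot speak for any other core.

The compounds shown leave open what an amine, a carboxylic acid or a nitrile would do in place of chloro. They also leave open whether the two cores would still match with such groups.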